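A few compounds are considered here, and "the series" means these few. Any claim that something is new, unique, unknown or untested is made for them only; others in the source may bear on it.

Measured compounds:
Compound 1, `CCOc1ccc(NC(=S)NNC(=O)c2ccncc2)cc1`: in an ADME assay on MCF-10A cells (Homo sapiens) for cytotoxicity, read by WST assay, with a stated time of 48 h (on this read-out lower numbers stand for stronger inhibition and higher numbers for weaker inhibition), compound 1 gives > 300000 nM, which is a limit of the assay.
Compound 2, `CC(=O)Nc1ccc(NC(=S)NNC(=O)c2ccncc2)cc1`: compound 2 gives > 300000 nM, again a limit.
Compound 3, `O=C(NNC(=S)Nc1ccc(I)cc1)c1ccncc1`: compound 3 gives > 300000 nM, also a limit.

Compound 3 therefore stands at the limit of > 300000 nM in this assay, at which 3 of the 3 values shown sit, with no number of its own. Compound 4, `O=C(NNC(=S)Nc1ccc(Cl)cc1)c1ccncc1`, differs from compound 3 by chloro in place of iodo on an aromatic carbon. The steps that touch compound 3, a step that the two limits leave unreadable from compound 1 to compound 3 and a step that the two limits leave unreadable from compound 2 to compound 3, give no readable size, and the same holds for a step that the two limits leave unreadable from compound 1 to compound 2. Among the measured compounds shown here, no measured step sets a direction, so the step of a number no higher from compound 3 to compound 4 (the limit leaves the size open) is expected to stay within the scatter. For compound 4 the expected value is 300000 nM, between 100000 nM and 1000000 nM, most likely again reported only as a limit.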

Compound 4, half-maximal inhibitory concentration: > 300000 nM
Compound 4: a limit, no number; the forecaster's own chance of this, stated with the estimate: 80%; the middle value lies on the limit itself.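

Among the compounds shown here, compound 4 also gives only a limit, so no step among compound 1, compound 2, compound 3 and compound 4 can be read: the limit of > 300000 nM in this assay, at which 4 of the 4 values shown sit. Still open, on these data alone, is whether exchanging these groups changes the cell result at all.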